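The compounds below may be only part of what the source reports. "The series", "measured", "known", "first", "only" and "open" are said of these compounds alone.

This account follows a single small change within a set of compounds tested in an ADME assay on GES1 cells (Homo sapiens) for inhibition, read by MTT assay, with a stated time of 72 h; a higher number here means a weaker inhibitor, a lower number a stronger inhibitor. Compound 1 `Cc1ccc(CSc2nc3nc(C)cc(Nc4cc(-c5ccccc5)[nH]n4)n3n2)cc1` gives 36200 nM in this assay. Compound 2 `Cc1cc(Nc2cc(-c3ccccc3)[nH]n2)n2nc(SCc3ccccc3Br)nc2n1` gives 41100 nM in this assay, and the step of a 1.1-fold higher number from compound 1 to compound 2 (0.06 log units; within the scatter) stays within the scatter. Compound 3 `Cc1ccc(Cn2ccc(Nc3cc(C)nc4nc(SCc5ccc(Br)cc5)nn34)n2)cc1` reaches only (the limit of > 50000 nM in this assay, at which 1 of the 3 values shown sits), so for compound 3 no number is known, only the limit > 50000 nM in this assay.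

Compound 4 `Cc1cc(Nc2ccn(Cc3ccccc3)n2)n2nc(SCc3ccc(Br)cc3)nc2n1` differs from compound 3 in one place: hydrogen in place of methyl on an aromatic carbon. Among the measured compounds shown here, no measured step touches this part of the structure. For the measured compounds named here, the one measured step, a 1.1-fold higher number from compound 1 to compound 2 (0.06 log units; within the scatter), changed the group on the saturated chain carbon bound to a sulfur, and that change, swapping 4-methylphenyl for 2-bromophenyl, stayed within the scatter. The present change is smaller still, trading a methyl for a hydrogen on an aromatic carbon, so the step that the limit leaves unreadable from compound 3 to compound 4 is expected to stay within the scatter as well. Since compound 3 already stands at the limit, compound 4 is most likely to return only a limit again; if a number appears, compound 4 is expected to give about 55000 nM, with a range from 25000 nM to 120000 nM in this assay.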

Compound 4, half-maximal inhibitory concentration: 44400 nM
Estimate against measurement, compound 4: 1.2-fold (0.09 log units) above, within the range that was stated.
By their numbers in this assay, from the lowest: compounds 1, 2 and 4 (each within the scatter of the next). At a limit, above all of these: compound 3.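

With the methyl gone, the 4-methylbenzyl group of compound 3 becomes the benzyl group of compound 4, and this side of the molecule now has a real number in this assay. The change reads as an at least 1.1-fold lower number from compound 3 to compound 4 (0.05 log units; that floor lies within the scatter), but that figure is only a floor: the true step could be that small or larger, and the data cannot say how much larger. Compound 3 gives no number, only a limit, so this position cannot be sized more closely than that floor: the limit of > 50000 nM in this assay, at which 1 of the 4 values shown sits.

On these data alone, whether a chlorine atom, a methoxy group or an amine on the same aromatic carbon would move the number in this assay stays open. Also open, as far as these compounds go, is how much the methyl itself matters, a question that needs a pair of compounds differing only in this methyl with a real number at both ends.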